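Working notes on a short antiproliferative series

The compounds below may be only part of what the source reports. "The series", "measured", "known", "first", "only" and "open" are said of these compounds alone.

In a functional assay on MCF7 cells (Homo sapiens) for antiproliferative activity (on this read-out lower numbers stand for stronger inhibition and higher numbers for weaker inhibition), compound 1 `COC(CN(c1ccccc1CO)S(=O)(=O)c1ccc([N+](=O)[O-])cc1)n1ccc(=O)[nH]c1=O` gives 45800 nM, the highest of the two numbers in hand; compound 2 `COc1ccc2c(c1)COC(n1cc(F)c(=O)[nH]c1=O)CO2` gives 1250 nM, a gap well beyond the scatter. Compound 3 `COC(CN(c1ccccc1CO)S(=O)(=O)c1ccc([N+](=O)[O-])cc1)n1cnc2c(Cl)ncnc21` differs from compound 1 by a group of 10 heavy atoms (5 carbon, 4 nitrogen, 1 chlorine; one five-membered aromatic ring with 2 hetero atoms, one six-membered aromatic ring with 2 hetero atoms) in place of a group of 8 heavy atoms (4 carbon, 2 nitrogen, 2 oxygen; one six-membered aromatic ring with 2 hetero atoms), on a saturated chain carbon bound to an oxygen on a saturated carbon and a saturated chain carbon. Going by the values given here, no measured pair shows this change, so its effect is open. The expected step is a 1.5-fold lower number from compound 1 to compound 3 (0.18 log units; within the scatter), a modest change that may not clear the scatter in either direction, since compound 1 already sits far up this assay. Compound 3 is therefore estimated at 30000 nM, with a range of 8000 nM to 150000 nM.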

Compound 3, half-maximal inhibitory concentration: 18700 nM
Beside the measured number, compound 3's estimate is 1.6-fold (0.21 log units) above it, and the stated range covers the measured number.
By their numbers in this assay, from the lowest: compound 2; then compound 3; then compound 1.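

Exchanging the group of 8 heavy atoms for the group of 10 heavy atoms, on a saturated chain carbon bound to an oxygen on a saturated carbon and a saturated chain carbon, gives a 2.4-fold lower number from compound 1 to compound 3 (0.39 log units; beyond the scatter) in this assay. This position therefore responds to the ring group it carries, although the step is modest. No measurement in hand accounts for this step.

On these data alone, whether an amine in place of the chlorine of compound 3 would move the number remains open. A single pair also cannot show which part of the exchanged group carries the step.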